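Phenyl to hydroxyethyl on the side chain of compound 1

This account rests on a few compounds, and the source may have more. Where it says the series, first, only, none or still open, it means among the compounds named here.

Measured so far:
compound 1 `CSc1nc(NCCCc2ccccc2)c2ccccc2n1` 39500 nM
compound 2 `CCCCC[Se]c1nc(N)c2cccnc2n1` 12900 nM

In a functional assay on CCRF-CEM cells (Homo sapiens) for cytotoxicity, read by MTT assay, with a stated time of 72 h (on this read-out lower numbers stand for stronger inhibition of growth and higher numbers for weaker inhibition of growth), compound 1 gives 39500 nM, the higher of the two numbers recorded. Compound 2 differs from compound 1 at several places and is not joined to it by a single step; in this assay compound 2 gives 12900 nM. The gap between the two values lies beyond the scatter, so compound 1 stands as the weaker of the pair.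

Compound 3 `CSc1nc(NCCCCCO)c2ccccc2n1` is not yet measured. It keeps the shared core of compound 1 and changes only the side chain: 2-hydroxyethyl in place of phenyl on a saturated chain carbon, three bonds along the chain from a nitrogen on an aromatic ring. Among the compounds with values here, no measured pair covers this change, so no step of known size can be read. Within the data shown here, the two compounds of the only available comparison give no guide, since they differ in the core rather than in this chain. The expectation is a step from compound 1 to compound 3 of a 1.4-fold higher number from compound 1 to compound 3 (0.14 log units; within the scatter), that is no change beyond the scatter, with some chance of a weaker number. The estimate for compound 3 is 55000 nM with a range of 15000 nM to 200000 nM in this assay, with a fair chance that only a limit is reported.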

Compound 3, concentration for 50% growth inhibition: > 100000 nM
Compound 3: no number, only a limit; the forecaster's own chance of this, stated with the estimate: 35%; middle value at least 1.8-fold (0.25 log units) away from the limit.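

In this assay compound 3 gives > 100000 nM, which is a limit of the assay and not a number. Placing 2-hydroxyethyl in place of phenyl on a saturated chain carbon, three bonds along the chain from a nitrogen on an aromatic ring, gives an at least 2.5-fold higher number from compound 1 to compound 3 (0.40 log units; beyond the scatter), so the only single-place change shown weakens growth inhibition at this position. The true size of that loss stays open, and the reading rests on a single limit: the limit of > 100000 nM in this assay, at which 1 of the 3 values shown sits.

These compounds cannot separate the loss of the phenyl ring from the entry of the hydroxyl group. A cyclohexyl group at this position would test the ring without its aromatic character, while an amine or a carboxylic acid at the chain end would show whether other groups there fare the same as 2-hydroxyethyl.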